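A few compounds are considered here, and "the series" means these few. Any claim that something is new, unique, unknown or untested is made for them only; others in the source may bear on it.

In a functional assay on FaDu cells (Homo sapiens) for cytotoxicity, read by MTT assay, with a stated time of 72 h (on this read-out lower numbers stand for higher toxicity in this test and higher numbers for lower toxicity in this test), three compounds have been measured so far:

Compound 1, `COCCn1cc(C(=O)C(=O)Nc2ccc(OC)nc2)c2cc(Cl)ccc21`, gives > 10000 nM.
Compound 2, `COCCc1cc(C(=O)C(=O)Nc2ccc(OC)nc2)c2ccccn12`, gives 36 nM.
Compound 3, `CC(C)Oc1ccc(NC(=O)C(=O)c2cn(C(C)C)c3ccccc23)cn1`, gives 408 nM.

The entry for compound 1 is not a number but a limit of the test, and the limit of > 10000 nM in this assay, at which 1 of the 3 values shown sits, marks where it sits. Within the data shown here, compound 2 and compound 3 both give plain numbers, and nothing in the set connects either of them to compound 1 by a single structural change, so no measured step is available to lean on.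

The next compound to be measured is compound 4, `COCCn1cc(C(=O)C(=O)Nc2ccc(OC)nc2)c2cc(OC)ccc21`. It differs from compound 1 in one place: methoxy in place of chloro on an aromatic carbon. Among the measured compounds shown here, with no single-change step among the measured compounds, the expected size of this step has to come from the change alone. Since the starting point is already a limit, the step expected in this assay is a step that the limit leaves unreadable from compound 1 to compound 4, that is, nothing beyond the usual scatter, and the most likely outcome is that compound 4 also returns only a limit. Compound 4 is therefore estimated at 15000 nM, with a range from 3000 nM to 60000 nM.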

Compound 4, concentration lethal to 50% of the cells: > 10000 nM
Compound 4: no number, only a limit; the forecaster's own chance of this, stated with the estimate: 70%; the middle value lies beyond the limit too.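

No size can be read for the change from chloro to methoxy between compound 1 and compound 4, because both compounds return a limit of the test rather than a number: the limit of > 10000 nM in this assay, at which 2 of the 4 values shown sit.

The compounds shown leave open how far either compound lies past that limit, and whether the two differ at all in this assay.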